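The source may hold more compounds than are shown below. What is called first, only, known or untested is meant among the compounds shown, and "the series" means these compounds.

Working notes on the series. Compound 1 `COc1cccc(Cn2ccc3nc(-c4ccccc4)nc-3c2)c1` gives in an ADME assay on MDBK cells (Bos taurus) for cytotoxicity (on this read-out higher numbers stand for lower toxicity in this test and lower numbers for higher toxicity in this test), only a limit of the assay, > 100000 nM. Compound 2 `CC(c1ccccc1)n1ccc2nc(-c3ccccc3)nc-2c1` likewise gives in this assay only a limit, > 100000 nM. Among the compounds with values here, both readings thus sit at the limit of > 100000 nM in this assay, at which 2 of the 2 values shown sit, so compound 1 stands where every value shown stands, and no step between measured compounds is available. Compound 3 `C(=C/c1ccccc1)\Cn1ccc2nc(-c3ccccc3)nc-2c1` differs from compound 1 by 2-phenylethenyl in place of 3-methoxyphenyl on a saturated chain carbon bound to an aromatic nitrogen. On the numbers shown, the step expected a number no higher from compound 1 to compound 3 (the limit leaves the size open) is none beyond the usual scatter. Compound 3 is estimated at 100000 nM, with a range from 40000 nM to 300000 nM.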

Compound 3, half-maximal cytotoxic concentration: 78000 nM
For compound 3 the middle estimate is 1.3-fold (0.11 log units) above the measured one, within the range that was stated.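

With 2-phenylethenyl in place of 3-methoxyphenyl on a saturated chain carbon bound to an aromatic nitrogen, this assay gives an at least 1.2-fold lower number from compound 1 to compound 3 (0.10 log units; that floor lies within the scatter). Within the data shown here, this change yields the first reading at this position that is a number and not a limit, so the step has only a floor and its full size stays unknown. The other readings remain limits: the limit of > 100000 nM in this assay, at which 2 of the 3 values shown sit.

The compounds shown leave open whether the step truly exceeds the scatter. They also leave open how an amine or a carboxylic acid at this position would read in this assay.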